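The compounds below may be only part of what the source reports. "The series", "measured", "known", "first", "only" and "open" are said of these compounds alone.

The measured compounds:
compound 1, `CCC(=O)N1CCC(CN(C2Cc3cc(C#N)ccc3N(Cc3cncn3C)C2)S(=O)(=O)c2ccccn2)CC1`, 0.5 10^-6 cm/s;
compound 2, `Cn1cncc1CN1CC(N(CC2CCN(C(=O)N3CCCC3)CC2)S(=O)(=O)c2ccccn2)Cc2cc(C#N)ccc21`, 0.6 10^-6 cm/s;
compound 3, `Cn1cncc1CN1CC(N(CC2CCN(C(=O)NC(C)(C)C)CC2)S(=O)(=O)c2ccccn2)Cc2cc(C#N)ccc21`, 0.6 10^-6 cm/s.

All three were tested in an ADME assay on Caco-2 cells (Homo sapiens) for permeability, in the apical to basolateral direction; a lower number here means that the compound crosses the layer more slowly, a higher number that the compound crosses the layer faster. Compound 3 stands level with compound 2 on the numbers shown, and the step of a 1.2-fold higher number from compound 1 to compound 3 (0.08 log units; within the scatter) is also within the scatter, so the three cannot be told apart here. Compound 4, `Cn1cncc1CN1CC(N(CC2CCN(C(=O)Nc3ccc(Br)cc3)CC2)S(=O)(=O)c2ccccn2)Cc2cc(C#N)ccc21`, has not yet been measured. It differs from compound 3 in one place: 4-bromophenyl in place of tert-butyl on an amide-type nitrogen. Among the compounds with values here, the steps that bear on this are the two other changes on a carbonyl carbon, a 1.2-fold higher number from compound 1 to compound 2 (0.08 log units; within the scatter) and no change at the digits printed from compound 2 to compound 3 (within the scatter), neither of which moved the number beyond the scatter. Within the data shown here, no measured step brings an aromatic ring into this position, so the expectation rests on those unchanged numbers. For compound 4 a step of a 1.2-fold higher number from compound 3 to compound 4 (0.07 log units; within the scatter) is expected. The estimate for compound 4 is 0.7 10^-6 cm/s, with a range from 0.3 10^-6 cm/s to 1.6 10^-6 cm/s.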

Compound 4, apparent permeability: 0.6 10^-6 cm/s
Compound 4: middle estimate off by 1.2-fold (0.07 log units), on the high side; the measured number falls inside the stated range.
By their numbers in this assay, from the lowest: compounds 1, 2, 3 and 4 (each within the scatter of the next).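

In this assay, the first aromatic ring on this amide-type nitrogen gives no change at the digits printed from compound 3 to compound 4 (within the scatter), so 4-bromophenyl and tert-butyl cannot be told apart here. The comparisons with the other carbonyl substituents give no change at the digits printed from compound 2 to compound 4 (within the scatter) and a 1.2-fold higher number from compound 1 to compound 4 (0.08 log units; within the scatter), so this aromatic ring also leaves the number within the scatter. No measurement shown explains this lack of separation. As far as these compounds go, whether a carboxylic acid or an amine in place of the bromine would move the number beyond the scatter remains open.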